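Swapping Hydroxy for Ethylamino on a Five-Membered Ring

A few compounds are considered here, and "the series" means these few. Any claim that something is new, unique, unknown or untested is made for them only; others in the source may bear on it.

In a functional assay on the whole organism for positive allosteric modulation, with Mus musculus as the target (on this read-out lower numbers stand for an effect already at smaller amounts and higher numbers for an effect only at larger amounts of compound), compound 1 `CCC(=O)N(c1ccc(Cl)c(Cl)c1)C1CCCC1O` gives 0.4 mg/kg. This is the lower of the two true numbers available, and the gap to compound 3 `CCC(=O)N(c1ccc(C)c(Cl)c1)C1CCCC1N(C)C`, which gives 1 mg/kg, lies beyond the usual scatter. Compound 2 `CCC(=O)N(c1cccc(C)c1)C1CCCCC1N(C)C` reads > 50 mg/kg, which is a limit of the assay and not a number.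

The next compound, compound 4 `CCNC1CCCC1N(C(=O)CC)c1ccc(Cl)c(Cl)c1`, has ethylamino in place of hydroxy on a saturated ring carbon. For the measured compounds named here, no pair of measured compounds differs by this change alone, so any forecast is rough. The nearest guide is compound 3, which has a nitrogen group on a saturated ring carbon and still gives 1 mg/kg. Compound 2 also has a nitrogen group on its ring, so such a group does not ensure a low number. In this assay, a moderate rise in the number is expected, with an estimated 3.8-fold higher number from compound 1 to compound 4 (0.57 log units; beyond the scatter). For compound 4 the estimated value is 1.5 mg/kg, with an expected range from 0.3 mg/kg to 8 mg/kg.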

Compound 4, dose for half-maximal effect: 0.2 mg/kg
Compound 4: middle estimate off by 7.5-fold (0.88 log units), on the high side; the whole stated range lies above it.
By their numbers in this assay, from the lowest: compounds 4 and 1 (each within the scatter of the next); then compound 3. At a limit, above all of these: compound 2.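

For the compounds shown here, this is the first comparison that changes one place alone. In this assay, putting ethylamino in place of hydroxy on a saturated ring carbon gives a 2.0-fold lower number from compound 1 to compound 4 (0.30 log units; within the scatter), so the two compounds cannot be told apart on this read-out. This place on the five-membered ring therefore accepts ethylamino, with 3 heavy atoms, as readily as hydroxy, with 1 heavy atom, and both groups carry 1 hydrogen-bond donor and 1 hydrogen-bond acceptor. Nothing measured here explains why the swap leaves the read-out within the scatter.

Going by these compounds, whether a longer chain on the nitrogen, a carboxylic acid or a plain amine would fit this place equally well remains open. Also open, on these data alone, is whether ethylamino behaves the same way on a six-membered ring or with other groups on the aromatic ring.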